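The compounds below may be only part of what the source reports. "The series", "measured", "known", "first", "only" and "open" are said of these compounds alone.

Measured so far:
Compound 1 `CCOC(=O)c1ccc(-c2nn(Cc3ccc(F)cc3)c3ccccc23)cc1`; in a functional assay on cells (Platelet, Homo sapiens) for inhibition (a lower number here means a stronger inhibitor, a higher number a weaker inhibitor), compound 1 gives > 10000 nM, which is a limit of the assay.
Compound 2 `CC(C)NC(=O)c1ccc(-c2nn(Cc3ccccc3)c3ccccc23)cc1`; compound 2 gives > 10000 nM, also a limit.
Compound 3 `CCOC(=O)/C=C/c1ccc(-c2nn(Cc3ccccc3)c3ccccc23)cc1`; compound 3 gives > 10000 nM, again a limit.

Compound 1 therefore stands at the limit and nowhere else; every value recorded in the series sits there (the limit of > 10000 nM in this assay, at which 3 of the 3 values shown sit). Among the measured compounds shown here, the single step between measured compounds, a step that the two limits leave unreadable from compound 2 to compound 3, cannot be read, both ends being limits.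

Compound 4 `CCOC(=O)c1ccc(-c2nn(-c3ccccc3)c3ccccc23)cc1` differs from compound 1 by phenyl in place of 4-fluorobenzyl on an aromatic nitrogen. For the measured compounds named here, no measured step bears on this change. With all values at the limit (the limit of > 10000 nM in this assay, at which 3 of the 3 values shown sit), no direction or size beyond the scatter can be expected, and a further limit is the likeliest outcome. Compound 4 is expected at 20000 nM, range 5000 nM to 100000 nM, an expected step that the limit leaves unreadable from compound 1 to compound 4.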

Compound 4, half-maximal inhibitory concentration: > 10000 nM
Compound 4: a limit, no number (the forecaster's own chance of this, stated with the estimate: 80%); the middle value lies beyond the limit too.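

Among the compounds shown here, compound 1 and compound 4 are both limits in this assay, and no step between them can be read. Whether any change to the shared core gives a measurable value remains open, with the series so far at one place: the limit of > 10000 nM in this assay, at which 4 of the 4 values shown sit.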